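Swapping the 3-nitrophenyl group for a dimethoxyphenyl group

A few compounds are considered here, and "the series" means these few. Any claim that something is new, unique, unknown or untested is made for them only; others in the source may bear on it.

Going by the values given here, in a functional assay on QGY-7703 cells (Homo sapiens) for cytotoxicity, read by MTT assay, with a stated time of 24 h (a lower number here means a stronger inhibitor, a higher number a weaker inhibitor), compound 1 `COc1cc(/C=C2\CN(S(=O)(=O)c3ccc(F)cc3)C/C(=C\c3ccccc3F)C2=O)cc(OC)c1OC` reads 13300 nM and compound 2 `COc1cc(/C=C2\CN(S(=O)(=O)c3ccc(F)cc3)C/C(=C\c3cccc([N+](=O)[O-])c3)C2=O)cc(OC)c1OC` reads 3270 nM as the lower of the two numbers so far. Compound 3 `COc1cc(/C=C2\CN(S(=O)(=O)c3ccc(F)cc3)C/C(=C\c3cc(OC)c(OC)c(OC)c3)C2=O)cc(OC)c1` has 3,5-dimethoxyphenyl in place of 3-nitrophenyl (3,5-dimethoxyphenyl in place of 3-nitrophenyl on a double-bonded chain carbon bound to a double-bonded ring carbon) on a double-bonded chain carbon bound to a double-bonded ring carbon. Among the compounds with values here, the only measured step bearing on this is a 4.1-fold lower number from compound 1 to compound 2 (0.61 log units; beyond the scatter) and it brought in the 3-nitrophenyl that now leaves, so a partial move toward a higher number is expected in this assay with this change. The expected step is a 2.3-fold higher number from compound 2 to compound 3 (0.36 log units; beyond the scatter) and no larger than the measured one. For compound 3 the estimated value is 7500 nM with 2500 nM to 22000 nM as its expected range.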

Compound 3, half-maximal inhibitory concentration: 5200 nM
Compound 3: middle estimate off by 1.4-fold (0.16 log units), on the high side, and the stated range covers the measured number.
By their numbers in this assay, from the lowest: compounds 2 and 3 (each within the scatter of the next); then compound 1.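

In this assay, the exchange of 3-nitrophenyl for 3,5-dimethoxyphenyl gives a 1.6-fold higher number from compound 2 to compound 3 (0.20 log units; within the scatter), so these two groups cannot be told apart at this place. Set against 2-fluorophenyl, 3,5-dimethoxyphenyl gives a 2.6-fold lower number from compound 1 to compound 3 (0.41 log units; beyond the scatter), which shows that the distance from compound 1 is not confined to the 3-nitrophenyl group. Nothing measured here gives a reason for this.

As far as these compounds go, whether an amine or a carboxylic acid on this double-bonded chain carbon would read like these groups remains open. So does whether a simple unsubstituted phenyl would stand nearer compound 1 or compound 3.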